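This account rests on a few compounds, and the source may have more. Where it says the series, first, only, none or still open, it means among the compounds named here.

Three pyridine-cored compounds have been measured in a functional assay on T47D cells (Homo sapiens) for inhibition; a higher number here means a weaker inhibitor, a lower number a stronger inhibitor. Compound 1, `Oc1ccccc1-c1cc(-c2ccccc2F)cc(-c2ccccc2O)n1`, reaches only the limit of this assay, giving > 50000 nM. Compound 2, `Oc1cccc(-c2cc(-c3ccccc3F)cc(-c3ccccc3O)n2)c1`, is the result of 3-hydroxyphenyl in place of 2-hydroxyphenyl on an aromatic carbon applied to compound 1; in this assay compound 2 gives 24200 nM, and the step is an at least 2.0-fold lower number from compound 1 to compound 2 (0.31 log units; beyond the scatter). The size of that step rests on a limit, as the limit of > 50000 nM in this assay, at which 1 of the 3 values shown sits, shows. Compound 3, `Oc1cccc(-c2cc(-c3ccccc3OC(F)(F)F)cc(-c3ccccc3O)n2)c1`, differs from compound 2 by trifluoromethoxy in place of fluoro on an aromatic carbon, and in this assay compound 3 gives 2680 nM, a step of a 9.0-fold lower number from compound 2 to compound 3 (0.96 log units; beyond the scatter). The difference between the core of compound 1 and the core of compound 3 is not broken down here.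

Compound 4, `Oc1cccc(-c2cc(-c3ccccc3OC(F)(F)F)cc(-c3cccc(O)c3)n2)c1`, has not yet been measured. It arises from compound 3 by 3-hydroxyphenyl in place of 2-hydroxyphenyl on an aromatic carbon, the same kind of change as that from compound 1 to compound 2, though the surroundings differ: in compound 3 the changed carbon is meta to a 3-hydroxyphenyl group and meta to a large group, whereas in compound 1 it is meta to a 2-fluorophenyl group and meta to a 2-hydroxyphenyl group. Because compound 1 to compound 2 gave an at least 2.0-fold lower number from compound 1 to compound 2 (0.31 log units; beyond the scatter), a step of similar size, a 2.7-fold lower number from compound 3 to compound 4 (0.43 log units; beyond the scatter), is expected here. Compound 4 is therefore estimated at 1000 nM, with a likely range from 300 nM to 3500 nM.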

Compound 4, half-maximal inhibitory concentration: 7950 nM
Estimate against measurement, compound 4: 8.0-fold (0.90 log units) below, and the stated range ends below it.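

The replacement of 2-hydroxyphenyl by 3-hydroxyphenyl gives a 3.0-fold higher number from compound 3 to compound 4 (0.47 log units; beyond the scatter) in this assay, which runs opposite to the earlier case of this change. The outcome of this change therefore did not carry from one core to the other in this series: the same change on two cores in this assay, an at least 2.0-fold lower number (0.31 log units; beyond the scatter) from compound 1 to compound 2 and a 3.0-fold higher number (0.47 log units; beyond the scatter) from compound 3 to compound 4, at least 6.1-fold (0.78 log units) apart, beyond the scatter of two such steps. Compound 1 stands at a limit, so the earlier step has no exact size, and two cores cannot show which difference in the surroundings turns the change around or how it would run on a third core: the limit of > 50000 nM in this assay, at which 1 of the 4 values shown sits.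

The compounds shown leave open whether trifluoromethoxy in place of fluoro would give a step of similar size on a core carrying two 3-hydroxyphenyl groups. They also leave open how an amine or a carboxylic acid in place of the hydroxy group on either of these rings would read in this assay.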